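Ester swap on a compound already at the stability limit

The compounds below may be only part of what the source reports. "The series", "measured", "known", "first", "only" and "open" are said of these compounds alone.

Compound 1 `CC(C)OC(=O)c1cccc(NC(=O)[C@@H]2C[C@H](SC3=C(C(=O)O)N4C(=O)[C@H]([C@@H](C)O)[C@H]4[C@H]3C)CN2)c1` — > 95%
Compound 2 `CC(C)OC(=O)C1=C(S[C@@H]2CN[C@H](C(=O)Nc3cccc(C(=O)OC(C)C)c3)C2)[C@H](C)[C@@H]2[C@@H]([C@@H](C)O)C(=O)N12` — > 95%

In a physicochemical assay for metabolic stability, read by LC-MS, in phosphate buffer, with a stated time of 3 h, at pH 7.4, tested at 50 uM (on this read-out lower numbers stand for a less stable compound and higher numbers for a more stable compound), compound 1 gives > 95%, which is a limit of the assay rather than a number. Compound 2 gives > 95%, again only a limit. Among the measured compounds shown here, the single step with readings on both sides, a step that the two limits leave unreadable from compound 1 to compound 2, therefore has no readable size because of the limit of > 95% in this assay, at which 2 of the 2 values shown sit. Compound 1 thus stands at the upper edge of what this assay reports, with nothing in the numbers to separate it from compound 2.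

Compound 3 `C[C@@H](O)[C@H]1C(=O)N2C(C(=O)O)=C(S[C@@H]3CN[C@H](C(=O)Nc4cccc(C(=O)OCC(F)(F)F)c4)C3)[C@H](C)[C@H]12` differs from compound 1 in one place: 2,2,2-trifluoroethyl in place of isopropyl on an oxygen next to a carbonyl group. For the measured compounds named here, no measured step makes this particular exchange; the one step that touches the same oxygen, a step that the two limits leave unreadable from compound 1 to compound 2, gives no size to lean on. The expectation is that compound 3 stays at the same limit, with a step of a number no higher from compound 1 to compound 3 (the limit leaves the size open) showing no size beyond the scatter. Compound 3 is estimated at 95%, within 82% to 99%.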

Compound 3, percent of the compound remaining: > 95%
Compound 3 gave a limit, no number; the forecaster's own chance of this, stated with the estimate: 65%; the middle value sits exactly at the limit.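

No step can be read between compound 1 and compound 3, because both readings are limits and not numbers: the limit of > 95% in this assay, at which 3 of the 3 values shown sit.

The compounds shown leave open how compound 1, compound 2 and compound 3 truly compare in this assay, and whether any group on that oxygen would give a readable number.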